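Cutting one methoxy from the trimethoxy aryl of compound 2

The source may hold more compounds than are shown below. What is called first, only, known or untested is meant among the compounds shown, and "the series" means these compounds.

Measured so far in a functional assay on SW-620 cells (Homo sapiens) for inhibition, read by sulforhodamine B assay, with a stated time of 48 h; a lower number here means that less compound is tolerated, a higher number that more compound is tolerated:
- compound 1, `COc1ccc(-c2cc(/C=C/C(=O)c3ccc(N)cc3)[nH]n2)cc1`: 56200 nM
- compound 2, `COc1cc(-c2cc(/C=C/C(=O)c3ccc(N)cc3)[nH]n2)cc(OC)c1OC`: > 100000 nM
- compound 3, `COc1cc(-c2cc(/C=C/C(=O)c3ccc(F)c(F)c3)[nH]n2)cc(OC)c1OC`: > 100000 nM

Compound 2 stands only at a limit of this assay, > 100000 nM, not at a number. Compound 3 likewise gives only a limit in this assay, > 100000 nM. Within the data shown here, the one change between these two, a step that the two limits leave unreadable from compound 2 to compound 3, is therefore unreadable in size. Compound 1 gives 56200 nM in this assay, a number rather than a limit.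

Compound 4, `COc1ccc(-c2cc(/C=C/C(=O)c3ccc(N)cc3)[nH]n2)cc1OC`, differs from compound 2 by hydrogen in place of methoxy on an aromatic carbon. Among the measured compounds shown here, no measured step bears directly on this change; the only measured step, from compound 2 to compound 3, alters a different part of the molecule and is unreadable. What the values of compound 1 and compound 2 show is that the trimethoxy compound sits at the limit where the monomethoxy compound gives a number. Compound 4 is expected to lie between them, with the step of an at least 1.2-fold lower number from compound 2 to compound 4 (0.09 log units; that floor lies within the scatter) estimated, and a value of about 80000 nM expected, in the range 40000 nM to 200000 nM, with a fair chance that only a limit is returned.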

Compound 4, concentration lethal to 50% of the cells: 82900 nM
Beside the measured number, compound 4's estimate is 1.0-fold (0.02 log units) below it; measured number inside the range.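

In this assay, hydrogen in place of methoxy on the aromatic carbon ortho to a methoxy group turns a limit into a number, with an at least 1.2-fold lower number from compound 2 to compound 4 (0.08 log units; that floor lies within the scatter) as the step. The same kind of change read upward gives a 1.5-fold higher number from compound 1 to compound 4 (0.17 log units; within the scatter) as a step, so methoxy and hydrogen at this kind of place are not told apart between these two compounds. Going by these compounds, the true size of the first step stays unknown, and only its floor can be read, because compound 2 gives only a limit: the limit of > 100000 nM in this assay, at which 2 of the 4 values shown sit.

The step between compound 2 and compound 3 cannot be read, so the group on the carbonyl carbon remains unresolved at the trimethoxy end of the series. On these data alone, whether a hydroxyl or an ethoxy group at this place would give a number clearly apart from compound 4 remains open.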